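The source may hold more compounds than are shown below. What is called first, only, known or untested is meant among the compounds shown, and "the series" means these compounds.

Going by the values given here, compound 2, `Nc1nc(SC2CCCC2)c2ncn(/C=C3/CC3(CO)CO)c2n1`, is one of two compounds so far tested in an ADME assay on CCRF-HSB-2 cells (Homo sapiens) for cytotoxicity, with a stated time of 7 days; on this read-out higher numbers stand for lower toxicity in this test and lower numbers for higher toxicity in this test. In this assay compound 2 gives 91000 nM, while compound 1, `CCCSc1nc(N)nc2c1ncn2/C=C1/CC1(CO)CO`, gives 98000 nM. Among the compounds with values here, the only measured step joining them is a 1.1-fold lower number from compound 1 to compound 2 (0.03 log units; within the scatter), so compound 2 holds the lowest of the two numbers, yet its value cannot be told apart from that of compound 1.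

Compound 3, `Nc1nc(SCc2ccccc2)c2ncn(/C=C3/CC3(CO)CO)c2n1`, is the next compound in line. Its difference from compound 2 is benzyl in place of cyclopentyl on a sulfur. Within the data shown here, the one measured step that bears on this change is the earlier exchange at the same sulfur, a 1.1-fold lower number from compound 1 to compound 2 (0.03 log units; within the scatter), which stayed within the scatter. Among the measured compounds shown here, with only that step to go on, a larger group on the same sulfur is expected to leave this assay roughly unchanged, so for compound 3 the step of a 1.1-fold lower number from compound 2 to compound 3 (0.06 log units; within the scatter) is expected to be small. Compound 3 is therefore estimated at 80000 nM in this assay, with a range from 30000 nM to 200000 nM.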

Compound 3, half-maximal cytotoxic concentration: > 100000 nM
Compound 3: a limit, no number; the forecaster's own chance of this, stated with the estimate: 25%; middle value at least 1.2-fold (0.09 log units) away from the limit.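

For compound 3 the reading is a limit of the test and not a number: the limit of > 100000 nM in this assay, at which 1 of the 3 values shown sits. Going by these compounds alone, with benzyl, an aromatic ring stands on the sulfur for the first time, and in place of cyclopentyl it gives an at least 1.0-fold higher number from compound 2 to compound 3 (0.04 log units; that floor lies within the scatter), while the comparison with the propyl compound, read as phenyl in place of ethyl on a saturated chain carbon bound to a sulfur, gives an at least 1.0-fold higher number from compound 1 to compound 3 (0.00 log units; that floor lies within the scatter). Going by these compounds, both steps are floors rather than measured sizes, so the new information in this assay is one-sided: an aromatic ring at this position brought no fall in the number, which would have meant higher toxicity in this test, but how far compound 3 lies past the limit stays unknown.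

The compounds shown carry only carbon groups on the sulfur, so they leave open whether a chain ending in an amine or a carboxylic acid would keep the number this high. They also leave open whether a much longer alkyl chain, or a benzyl ring bearing a chlorine or a methoxy group, would bring it down into the range the test can measure.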